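The compounds below may be only part of what the source reports. "The series", "measured", "known", "first", "only" and "open" are said of these compounds alone.

Compound 1 `CCN(Cc1ccccc1)C(=O)C1CCN(S(=O)(=O)c2cccc(OC)c2)CC1` gives 3090 nM; 3100 nM (2 entries) in a functional assay on CHO cells for positive allosteric modulation of muscarinic acetylcholine receptor M5 (Homo sapiens), read by calcium flux; a lower number here means that less compound is needed, a higher number that more compound is needed for the effect. Compound 2 `CCN(Cc1ccccc1)C(=O)C1CCN(S(=O)(=O)c2ccncc2)CC1` carries a pyridin-4-yl group on the sulfonyl sulfur, and in this assay compound 2 reaches only the limit > 10000 nM, which is not a number, as the limit of > 10000 nM in this assay, at which 1 of the 2 values shown sits, shows. Compound 3 `CCN(Cc1ccccc1)C(=O)C1CCN(S(=O)(=O)c2cccc3nsnc23)CC1` differs from compound 2 by a group of 9 heavy atoms (6 carbon, 2 nitrogen, 1 sulfur; one five-membered aromatic ring with 3 hetero atoms, one six-membered aromatic ring of carbon only) in place of a group of 6 heavy atoms (5 carbon, 1 nitrogen; one six-membered aromatic ring with 1 hetero atom), on a sulfonyl sulfur. Within the data shown here, no measured step between two compounds differing in one place is known here, so the expectation rests on the two values alone. Compound 3 is estimated at 3000 nM, with a range from 800 nM to 15000 nM. That estimate means an expected step of an at least 3.3-fold lower number from compound 2 to compound 3 (0.52 log units; beyond the scatter), a gain beyond the scatter, though the limit of compound 2 leaves its size uncertain.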

Compound 3, half-maximal effective concentration: > 10000 nM
Compound 3 was reported as a limit; the forecaster's own chance of this, stated with the estimate: 35%; at least 3.3-fold (0.52 log units) between middle value and limit.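

In this assay, compound 2 and compound 3 are both reported only as limits, not as numbers, so the step between them cannot be read. On these data alone, whether exchanging the pyridin-4-yl group for the larger two-ring group changes the needed concentration at all remains open.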